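This account rests on a few compounds, and the source may have more. Where it says the series, first, only, none or still open, it means among the compounds named here.

Working notes on the series. Three compounds on a shared core have been run in an in vitro ADME assay on microsomes from liver (Mus musculus) for metabolic stability; on this read-out higher numbers stand for fast clearance and lower numbers for slow clearance. Compound 1 `COCc1nc2nc(C)cc(Nc3ccc(C(F)(F)F)cc3)n2n1` gives 13.3 mL.min-1.g-1. Compound 2 `CCc1nc2nc(C)cc(Nc3ccc(C(F)(F)F)cc3)n2n1` gives 14.4 mL.min-1.g-1. Compound 3 `Cc1cc(Nc2ccc(C(F)(F)F)cc2)n2nc(CCO)nc2n1` gives 6.9 mL.min-1.g-1, the lowest of the three numbers; its nearest neighbour is compound 1, with a 1.9-fold lower number from compound 1 to compound 3 (0.29 log units; within the scatter) separating the two, and its furthest is compound 2, reached by a 2.1-fold lower number from compound 2 to compound 3 (0.32 log units; beyond the scatter). Compound 1 and compound 2 sit close together, as seen in a 1.1-fold higher number from compound 1 to compound 2 (0.03 log units; within the scatter).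

The next compound, compound 4 `CCOc1nc2nc(C)cc(Nc3ccc(C(F)(F)F)cc3)n2n1`, differs from compound 3 by ethoxy in place of 2-hydroxyethyl on an aromatic carbon. Two of the measured steps bear on this. The step from compound 2 to compound 3, a 2.1-fold lower number from compound 2 to compound 3 (0.32 log units; beyond the scatter), introduced the hydroxy group that compound 4 again lacks; the step from compound 1 to compound 3, a 1.9-fold lower number from compound 1 to compound 3 (0.29 log units; within the scatter), swapped a methoxy for a hydroxymethyl and was of similar size, though within the scatter. Compound 4 carries an ethoxy, closer in kind to the methoxy of compound 1 and the ethyl of compound 2 than to the hydroxy-bearing chain of compound 3, so a return toward those two values is expected in this assay, a modest upward step of roughly a 1.7-fold higher number from compound 3 to compound 4 (0.24 log units; within the scatter). Compound 4 is therefore estimated at 12 mL.min-1.g-1, with a range from 7 mL.min-1.g-1 to 22 mL.min-1.g-1.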

Compound 4, intrinsic clearance in microsomes: 14.4 mL.min-1.g-1
For compound 4 the middle estimate is 1.2-fold (0.08 log units) below the measured one; low and high end bracket the measured number.
By their numbers in this assay, from the lowest: compounds 3, 1, 2 and 4 (each within the scatter of the next, the first and the last beyond it).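

The swap of 2-hydroxyethyl for ethoxy on this aromatic carbon, between two ring nitrogen atoms, keeps the same atoms but removes the hydrogen-bond donor, and in this assay it gives a 2.1-fold higher number from compound 3 to compound 4 (0.32 log units; beyond the scatter) as a step beyond the scatter. Ethoxy reads the same as the other two groups without a hydroxy, with no change at the digits printed from compound 2 to compound 4 (within the scatter) against ethyl and a 1.1-fold higher number from compound 1 to compound 4 (0.03 log units; within the scatter) against methoxymethyl, so on these compounds an oxygen bound directly to the ring carbon, an oxygen one carbon along the chain and no oxygen at all cannot be told apart; compound 3, the only compound with a hydroxy, is separated from compound 2 and compound 4 by steps beyond the scatter, but compound 1 goes against a clean split, with a 1.9-fold lower number from compound 1 to compound 3 (0.29 log units; within the scatter) still inside it. No measurement available here accounts for any of these steps.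

On these data alone, whether the lower number follows the hydroxy itself or only this 2-hydroxyethyl chain stays open, as a hydroxymethyl or a longer hydroxyalkyl chain at this position would be needed to separate the two. How an amine or a carboxylic acid at the same carbon would read in this assay also remains unknown from the compounds shown.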